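Removing both methyl groups from the dipeptide chain of compound 3

The source may hold more compounds than are shown below. What is called first, only, known or untested is meant among the compounds shown, and "the series" means these compounds.

Compound 3, with structure `COC(=O)[C@H](C)NC(=O)[C@H](C)NC(=O)Cn1cc(CN(Cc2ccccn2)Cc2ccccn2)nn1`, gives 96000 nM in an ADME assay on COLO357 cells (Homo sapiens) for cytotoxicity, read by MTT assay, with a stated time of 72 h (on this read-out lower numbers stand for stronger inhibition and higher numbers for weaker inhibition), the second highest of the three numbers measured. Its mirror image, compound 2 with structure `COC(=O)[C@@H](C)NC(=O)[C@@H](C)NC(=O)Cn1cc(CN(Cc2ccccn2)Cc2ccccn2)nn1`, gives 133000 nM, and the step of a 1.4-fold lower number from compound 2 to compound 3 (0.14 log units; within the scatter) shows that inverting both stereocentres changes little. Compound 1, with structure `COC(=O)[C@@H](C)NC(=O)[C@@H](C)NC(=O)CN(C)CCN(Cc1ccccn1)Cc1ccccn1`, gives 4300 nM. Compound 4, with structure `COC(=O)CNC(=O)CNC(=O)Cn1cc(CN(Cc2ccccn2)Cc2ccccn2)nn1`, carries the change ((((methoxycarbonyl)methyl)carbamoyl)methyl in place of 1-((1-(methoxycarbonyl)ethyl)carbamoyl)ethyl on an amide-type nitrogen), which removes both stereocentres. Within the data shown here, no measured step probes this exact change; the only step touching the same chain, from compound 2 to compound 3, stays within the scatter. A step of a 1.0-fold higher number from compound 3 to compound 4 (0.02 log units; within the scatter) is therefore expected, with no clear direction. Compound 4 is estimated at 100000 nM, between 35000 nM and 280000 nM.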

Compound 4, half-maximal inhibitory concentration: 137000 nM
The estimate for compound 4 lay 1.4-fold (0.14 log units) below the measured number; the range from low to high includes it.
By their numbers in this assay, from the lowest: compound 1; then compounds 3, 2 and 4 (each within the scatter of the next).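

In this assay, the steps of a 1.4-fold higher number from compound 3 to compound 4 (0.15 log units; within the scatter) and a 1.0-fold higher number from compound 2 to compound 4 (0.01 log units; within the scatter) show that the chain can lose both methyl groups, not merely have them inverted, and the numbers remain within the scatter. The earlier pair could speak only to how these methyl groups are oriented, for one plain reason: the fact that compounds 2 and 3 differ only in the configuration as drawn

As far as these compounds go, whether a benzyl group at these chain carbons, or a carboxylic acid in place of the methyl ester, would shift the number remains open. So does whether removing the methyl groups would matter on the chain of compound 1.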